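Bromo to methyl in a weakly active series

This account rests on a few compounds, and the source may have more. Where it says the series, first, only, none or still open, it means among the compounds named here.

Of the compounds shown here, two have been read so far in a functional assay on DU-145 cells (Homo sapiens) for inhibition, read by trypan blue exclusion, with a stated time of 96 h; a lower number here means a stronger inhibitor of growth, a higher number a weaker inhibitor of growth. Among the measured compounds shown here, compound 1 `Cc1ccc(S(=O)(=O)/C(=C/c2sccc2C)C(=O)c2ccc(Cl)cc2)cc1` gives 10000 nM, the only numeric reading. Compound 2 `CN(C)c1ccc(/C=C(\C(=O)c2ccc(Cl)cc2)S(=O)(=O)c2ccc(Br)cc2)cc1` is reported only as a limit, > 100000 nM. Its true position is therefore unknown, and any step starting from it can only be estimated.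

Compound 3 `Cc1ccc(S(=O)(=O)/C(=C/c2ccc(N(C)C)cc2)C(=O)c2ccc(Cl)cc2)cc1` differs from compound 2 by a single change methyl in place of bromo on an aromatic carbon, para to a large group, which turns 4-bromophenyl into 4-methylphenyl.

For the measured compounds named here, no measured step sizes this change. The expectation rests in part on the limit held by compound 2. Otherwise it rests only on the reading of compound 1 at 10000 nM, which marks the level at which a number has been obtained. A modest move toward stronger growth inhibition is expected, though compound 3 may again return only a limit. The expected change is an at least 2.5-fold lower number from compound 2 to compound 3 (0.39 log units; beyond the scatter). For compound 3 the estimated value is 40000 nM, with an expected range of 8000 nM to 100000 nM.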

Compound 3, concentration for 50% growth inhibition: > 100000 nM
Compound 3 was reported as a limit (the forecaster's own chance of this, stated with the estimate: 40%); middle value at least 2.5-fold (0.39 log units) from the limit.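

In this assay compound 3 gives > 100000 nM, which is a limit and not a number, so methyl in place of bromo on this aromatic carbon, para to a large group, leaves the series without a size for this change; the step cannot be read, since both of its ends are limits: the limit of > 100000 nM in this assay, at which 2 of the 3 values shown sit.

The result does give one readable step at the other place of variation, where 4-(dimethylamino)phenyl stands in place of 3-methylthiophen-2-yl on the double-bonded chain carbon: an at least 10-fold higher number from compound 1 to compound 3 (1.00 log units; beyond the scatter). Among these compounds, 4-methylphenyl alone does not secure a numeric reading, as compound 3 carries it and still returns only a limit, while the single number belongs to compound 1, which pairs it with 3-methylthiophen-2-yl.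

Open, going by these compounds, is how bromo and methyl compare where a number can be obtained, which would take a 4-bromophenyl partner of compound 1. Also open, on these data alone, is whether an amine or a carboxylic acid on this aromatic carbon, in place of methyl, would alter the reading on the core of compound 1.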